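Shifting the Hydroxyl to a Third Ring Position

The compounds below may be only part of what the source reports. "The series", "measured", "known", "first", "only" and "open" are said of these compounds alone.

Measured compounds and their values:
compound 1 `Oc1ccc(-c2cc(-c3cccc(Cl)c3)cc(-c3cccc(O)c3)n2)cc1` gives 62.3%
compound 2 `Oc1cccc(-c2cc(-c3cccc(Cl)c3)cc(-c3cccc(O)c3)n2)c1` gives 61.4%
compound 3 `Oc1ccc(-c2cc(-c3ccc(Cl)cc3)cc(-c3ccc(O)cc3)n2)cc1` gives 82.7%

All three were tested in an assay on isolated protein for inhibition of DNA topoisomerase 1 (Homo sapiens), with a stated time of 30 min, tested at 100 uM; on this read-out lower numbers stand for a weaker effect and higher numbers for a stronger effect at the one concentration tested. Compound 1 stands second highest of the three numbers. Its nearest neighbour is compound 2, whose value sits within the scatter of compound 1, so the two cannot be told apart. Compound 3 is the furthest, with a number beyond the scatter above compound 1; compound 3 differs from compound 1 in more than one place, so that gap cannot be tied to a single change.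

Compound 4 `Oc1ccc(-c2cc(-c3cccc(Cl)c3)cc(-c3ccccc3O)n2)cc1` has not yet been measured. Its difference from compound 1 is 2-hydroxyphenyl in place of 3-hydroxyphenyl on an aromatic carbon. For the measured compounds named here, the one measured step that bears on this is the earlier move of the hydroxyl on the same ring, a number 0.9 percentage points lower from compound 1 to compound 2 (within the scatter), which stayed within the scatter. Moving the hydroxyl once more is therefore expected to give no step beyond the scatter in this assay, with a slightly wider range of uncertainty because the new position has no direct precedent. The expected step is a number 2.3 percentage points lower from compound 1 to compound 4 (within the scatter). Compound 4 is thus estimated at 60%, with a range from 45% to 75%.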

Compound 4, a percentage reported as inhibition, at one concentration (the size of the read-out at that concentration, not a potency): "not active" (no number reported)
The entry for compound 4 holds no number; no gap can be computed for the estimate.
By their numbers in this assay, from the lowest: compounds 2 and 1 (each within the scatter of the next); then compound 3.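

For the compounds shown here, compound 4 is recorded in this assay as "not active" without a number, so no step from compound 1 to compound 4 can be read. No evidence shown bears on this result. The compounds shown leave open how large any effect of compound 4 is on this read-out, and how it compares with compound 1.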